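A few compounds are considered here, and "the series" means these few. Any claim that something is new, unique, unknown or untested is made for them only; others in the source may bear on it.

Measured so far:
compound 1 `COc1cc(-c2nn(-c3cccc(NC(=O)Nc4cc(C(F)(F)F)cc(C(F)(F)F)c4)c3)cc2-c2ccncc2)ccc1Cl` — 3340 nM
compound 2 `COc1cc(-c2nn(-c3cccc(NC(=O)Nc4ccc(Cl)c(Cl)c4)c3)cc2-c2ccncc2)ccc1Cl` — 5190 nM

The two values come from a functional assay on NCI-H23 cells (Homo sapiens) for inhibition, read by sulforhodamine B assay, with a stated time of 48 h; a lower number here means a stronger inhibitor of growth, a higher number a weaker inhibitor of growth. Compound 1 `COc1cc(-c2nn(-c3cccc(NC(=O)Nc4cc(C(F)(F)F)cc(C(F)(F)F)c4)c3)cc2-c2ccncc2)ccc1Cl` gives 3340 nM there, and compound 2 `COc1cc(-c2nn(-c3cccc(NC(=O)Nc4ccc(Cl)c(Cl)c4)c3)cc2-c2ccncc2)ccc1Cl` gives 5190 nM. Of the two numbers, that of compound 2 is the higher, but the gap to compound 1 lies within the usual scatter, so the two cannot be told apart on these data.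

Compound 3 `COc1cc(-c2nn(-c3cccc(NC(=O)Nc4cccc(C(F)(F)F)c4)c3)cc2-c2ccncc2)ccc1Cl` differs from compound 2 in one place: 3-(trifluoromethyl)phenyl in place of 3,4-dichlorophenyl on an amide-type nitrogen. Among the measured compounds shown here, no measured pair shows this change, so its effect in this assay is open. Compound 1 and compound 2 show that a urea aryl group with halogen-bearing substituents gives numbers of this size, and a single trifluoromethyl group is expected to keep compound 3 in the same region, with no step beyond the scatter, so the expected step is a 1.2-fold higher number from compound 2 to compound 3 (0.06 log units; within the scatter). For compound 3 the estimate is 6000 nM, with a range from 2500 nM to 15000 nM.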

Compound 3, concentration for total growth inhibition: 3410 nM
Estimate against measurement, compound 3: 1.8-fold (0.25 log units) above, and the stated range covers the measured number.
By their numbers in this assay, from the lowest: compounds 1, 3 and 2 (each within the scatter of the next).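

In this assay, the first direct test of this position, 3-(trifluoromethyl)phenyl in place of 3,4-dichlorophenyl on the amide-type nitrogen gives a 1.5-fold lower number from compound 2 to compound 3 (0.18 log units; within the scatter), and hydrogen in place of trifluoromethyl on an aromatic carbon gives a 1.0-fold higher number from compound 1 to compound 3 (0.01 log units; within the scatter). Both steps lie within the scatter, so on these data neither the swap of the chlorines for one trifluoromethyl nor the loss of the second trifluoromethyl separates the compounds. No measurement at hand says why these numbers stay together.

All three compounds shown carry fluorine or chlorine on this aryl ring, so it remains open what a plain phenyl, or a phenyl bearing an amine or a carboxylic acid, would give at this place. As far as these compounds go, whether any change here can move the number beyond the scatter also remains open.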